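A few compounds are considered here, and "the series" means these few. Any claim that something is new, unique, unknown or untested is made for them only; others in the source may bear on it.

The study gathers three flavone-type compounds that share a core and differ in the substituents and placement of the fused bicyclic amine. Compound 1 `O=c1cc(-c2ccccc2)oc2cc(N3COc4ccccc4C3)ccc12` carries that amine unsubstituted; in a functional assay on MCF7 cells (Homo sapiens) for inhibition, read by MTT assay, with a stated time of 48 h, tested at 60 ug/mL (on this read-out higher numbers stand for more inhibition of growth at the one concentration tested and lower numbers for less inhibition of growth), compound 1 gives 19.3%. Compound 2 `O=c1cc(-c2ccccc2)oc2ccc(N3COc4c(cccc4[N+](=O)[O-])C3)cc12` bears a nitro group, and in this assay compound 2 gives 72.9%. Compound 3 `O=c1cc(-c2ccccc2)oc2ccc(N3COc4c(Cl)cc(Cl)cc4C3)cc12` bears two chlorines, and in this assay compound 3 gives 80.3%. Compound 2 thus stands second highest of the three numbers: its nearest neighbour is compound 3, whose value lies within the scatter of it, while compound 1 lies far below it, beyond the scatter.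

Compound 4 `Cc1cccc2c1OCN(c1ccc3oc(-c4ccccc4)cc(=O)c3c1)C2` has not yet been measured. It arises from compound 2 by a single change: methyl in place of nitro on an aromatic carbon

Among the measured compounds shown here, no measured pair shows this change directly. For the measured compounds named here, the only unsubstituted analogue, compound 1, differs from compound 4 in more than one place, so its value offers only a rough hint that removing polar substituents may lower the number. Compound 4 is therefore expected to fall somewhat below compound 2, with a step of a number 20.9 percentage points lower from compound 2 to compound 4 (beyond the scatter) that may or may not exceed the scatter. Compound 4 is estimated to give 52%, within a range from 28% to 76%.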

Compound 4, percent growth inhibition at one concentration: 85.1%
Compound 4: the middle estimate sits 33.1 percentage points below what was measured; the measured number lies above the stated range.
By their numbers in this assay, from the lowest: compound 1; then compounds 2, 3 and 4 (each within the scatter of the next, the first and the last beyond it).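

In this assay, putting methyl in place of nitro on this aromatic carbon gives a number 12.2 percentage points higher from compound 2 to compound 4 (beyond the scatter) and so counts as a modest rise. Among the compounds shown here, this is the first direct reading of a change at this position, since no earlier pair of compounds differed in one place. It shows that, on this core and at the one concentration tested, the number does not depend on the nitro group with its three heavy atoms and two hydrogen-bond acceptors: a single carbon with no hydrogen-bond acceptors, on an aromatic carbon ortho to a fused ring, carries a higher number. Nothing available explains why the smaller group gives more inhibition of growth, so the result stands as an observation only.

What the compounds shown leave open is how far this finding extends, as two compounds that differ in one place cannot define a trend at this position. Going by these compounds, whether plain hydrogen, an amine, a carboxylic acid or a longer chain such as ethyl on this same aromatic carbon would keep, raise or lower the number remains unknown.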